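The source may report more compounds than this note shows. Statements on the series, on what has been measured and on what is new or still open speak of the compounds shown alone.

Measured so far:
- compound 1 `CCCCn1cc(C(=O)C(=O)Nc2ccc(OC)nc2)c2ccccc21`: in a functional assay on FaDu cells (Homo sapiens) for cytotoxicity, read by MTT assay, with a stated time of 72 h (a higher number here means that more compound is tolerated, a lower number that less compound is tolerated), compound 1 gives 18 nM
- compound 2 `COc1ccc(NC(=O)C(=O)c2cn(C(C)C)c3ccccc23)cc1OC`: in this assay compound 2 gives > 10000 nM

Within the data shown here, compound 1 holds the only numerical reading of the series in this assay. For compound 2 the assay returned a limit rather than a number, so compound 2 stands at the limit of > 10000 nM in this assay, at which 1 of the 2 values shown sits. Among the measured compounds shown here, of the pair compound 1 and compound 2 nothing more can be said than that one reading is a number and the other a limit, and no measured step connects them.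

Compound 3 `COc1ccc(NC(=O)C(=O)c2cn(C3CCCC3)c3ccccc23)cn1` keeps the rest of compound 1 unchanged and differs from it in one place: cyclopentyl in place of butyl on an aromatic nitrogen. For the measured compounds named here, no measured pair in this assay shows a step of this kind, so the expectation rests on the change itself, a change of one carbon in a saturated group on the same aromatic nitrogen. The step from compound 1 to compound 3 is expected to stay within the usual scatter, with no direction beyond it: a 1.4-fold higher number from compound 1 to compound 3 (0.14 log units; within the scatter). Compound 3 is therefore estimated at 25 nM in this assay, with a range from 6 nM to 100 nM.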

Compound 3, concentration lethal to 50% of the cells: 370 nM
The estimate for compound 3 lay 15-fold (1.17 log units) below the measured number; the measured number lies above the stated range.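

In this assay the group on the aromatic nitrogen proves to be a sensitive place in the core of compound 1: cyclopentyl in place of butyl gives a 21-fold higher number from compound 1 to compound 3 (1.31 log units; beyond the scatter), with the rest of the structure unchanged. Among these compounds, until now no measured pair differed in one place, so this is the first direct reading of this position, and it shows that exchanging an open chain for a saturated carbon ring is enough for a step beyond the scatter, although neither group carries a hydrogen-bond donor, a hydrogen-bond acceptor or a net charge. Nothing measured in the series gives a cause for this step.

A single pair cannot separate the effect of the ring from that of the larger group or of branching at the carbon on the nitrogen, and a pentyl chain, an isobutyl group or a cyclopropyl ring at this position would each bear on that question. Also open, going by these compounds, is whether a step of this size holds when the group on the amide nitrogen is something else, such as a phenyl ring carrying a carboxylic acid.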